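Trimming the Sulfur Side Chain: Compound 1 to Compound 3

The source may hold more compounds than are shown below. What is called first, only, known or untested is meant among the compounds shown, and "the series" means these compounds.

Compound 1 `Cc1cc(Nc2cc(-c3ccccc3)[nH]n2)n2nc(SCC(=O)c3ccccc3)nc2n1`: 33300 nM
Compound 2 `Cc1cc(Nc2cc(-c3ccc(F)cc3)[nH]n2)n2nc(SCc3ccc(Br)cc3)nc2n1`: 34200 nM

In an ADME assay on GES1 cells (Homo sapiens) for inhibition, read by MTT assay, with a stated time of 72 h (on this read-out higher numbers stand for weaker inhibition and lower numbers for stronger inhibition), compound 1 gives 33300 nM and compound 2 gives 34200 nM; the two numbers lie within the scatter of each other, so neither stands apart. Compound 3 `CCCSc1nc2nc(C)cc(Nc3cc(-c4ccccc4)[nH]n3)n2n1` has not yet been measured. It differs from compound 1 in one place: ethyl in place of benzoyl on a saturated chain carbon bound to a sulfur. For the measured compounds named here, no step between measured compounds is available to lean on, so the expected change from compound 1 to compound 3 is a 1.2-fold higher number from compound 1 to compound 3 (0.08 log units; within the scatter), a step not expected to reach beyond the scatter in either direction. Compound 3 is therefore estimated at 40000 nM, within a range from 15000 nM to 100000 nM.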

Compound 3, half-maximal inhibitory concentration: > 50000 nM
Compound 3: only a limit was reported (the forecaster's own chance of this, stated with the estimate: 20%); middle value at least 1.2-fold (0.09 log units) from the limit.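

In this assay compound 3 gives > 50000 nM, which is a limit of the assay and not a number. Ethyl in place of benzoyl on a saturated chain carbon bound to a sulfur gives the first one-place comparison at this position: an at least 1.5-fold higher number from compound 1 to compound 3 (0.17 log units; that floor lies within the scatter). How far the true value lies past that floor cannot be told: the limit of > 50000 nM in this assay, at which 1 of the 3 values shown sits.

Going by these compounds, because benzoyl leaves as a whole, the separate roles of its ring and its carbonyl remain open. Also open, on these data alone, is how a butyl chain or a chain ending in an amine would read here.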